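A few compounds are considered here, and "the series" means these few. Any claim that something is new, unique, unknown or untested is made for them only; others in the source may bear on it.

Of the compounds shown here, three sharing one core have been tested in an ADME assay on microsomes from liver (Homo sapiens) for metabolic stability; a lower number here means that the compound disappears faster, a higher number that the compound lasts longer. Compound 3 `CCCNC(=O)C1CCN(C(=O)c2cc3sccc3n2Cc2ccc(OC)cc2)CC1` gives 0.177 h, the lowest single number among the two compounds that have one; compound 1 `CCCNC(=O)C1CCN(C(=O)c2cc3sc(C#N)cc3n2Cc2ccc(OC)cc2)CC1` gives 0.187 h, and the step of a 1.1-fold lower number from compound 1 to compound 3 (0.02 log units; within the scatter) stays within the scatter. Compound 2 `CCCNC(=O)C1CCN(C(=O)c2cc3sc(Br)cc3n2Cc2ccc(OC)cc2)CC1` gives 0.0485 h; 0.0588 h (2 entries), two entries rather than one number, (the several entries of compound 2 in this assay, 0.0485 h; 0.0588 h (2 entries)), both below the value of compound 3. Compound 4 `CCCNC(=O)C1CCN(C(=O)c2cc3sc(-c4ccccc4F)cc3n2Cc2ccc(OC)cc2)CC1` is not yet measured; it differs from compound 3 by 2-fluorophenyl in place of hydrogen on an aromatic carbon. Among the measured compounds shown here, no measured step covers a change of this kind: the only one, from compound 1 to compound 3, was small, while compound 2 with its bromine shows lower numbers. The expected step is therefore a modest drop, a 1.8-fold lower number from compound 3 to compound 4 (0.25 log units; within the scatter). Compound 4 is estimated at 0.1 h, within a range from 0.04 h to 0.25 h.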

Compound 4, half-life: 0.592 h
Compound 4: middle estimate off by 5.9-fold (0.77 log units), on the low side; measured number outside the range, above it.
By their numbers in this assay, from the lowest: compounds 3 and 1 (each within the scatter of the next); then compound 4.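

In this assay, a substituent on the aromatic carbon next to the ring sulfur can lengthen the half-life: the change gives a 3.3-fold higher number from compound 3 to compound 4 (0.52 log units; beyond the scatter), and replacing cyano with 2-fluorophenyl gives a 3.2-fold higher number from compound 1 to compound 4 (0.50 log units; beyond the scatter). Among the compounds shown here, earlier, the only step at this position, from cyano to hydrogen, stayed within the scatter. Not every group here goes the same way, as bromine in compound 2 gives numbers below that of compound 4: the several entries of compound 2 in this assay, 0.0485 h; 0.0588 h (2 entries)

On these data alone, whether the longer half-life goes with the ring or with its fluorine remains open. Phenyl without the fluorine would separate the two, and an amine on that ring would show how far the trend extends.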